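The source may report more compounds than this note shows. Statements on the series, on what has been measured and on what is new or still open speak of the compounds shown alone.

In an ADME assay on HEK293 cells (Homo sapiens) for cytotoxicity, read by MTT assay, with a stated time of 48 h (a higher number here means a weaker inhibitor, a lower number a stronger inhibitor), three compounds on a shared core have been measured so far: compound 1 `O=C1/C(=C\c2ccc(O)cc2)S/C(=N/c2ccccc2)N1Cc1ccncc1` gives 142000 nM, compound 2 `O=C1/C(=C\c2ccc([N+](=O)[O-])cc2)S/C(=N/c2ccccc2)N1Cc1ccncc1` gives 250000 nM and compound 3 `COc1ccc(/C=C2/S/C(=N/c3ccccc3)N(Cc3ccncc3)C2=O)cc1OC` gives 171000 nM. Compound 3 stands within the scatter of both others, with a 1.2-fold higher number from compound 1 to compound 3 (0.08 log units; within the scatter) and a 1.5-fold lower number from compound 2 to compound 3 (0.16 log units; within the scatter). The remaining pair is also within the scatter, with a 1.8-fold higher number from compound 1 to compound 2 (0.25 log units; within the scatter). Compound 4 `Cc1ccc(/C=C2/S/C(=N/c3ccccc3)N(Cc3ccncc3)C2=O)s1` has not yet been measured. It differs from compound 3 by 5-methylthiophen-2-yl in place of 3,4-dimethoxyphenyl on a double-bonded chain carbon bound to a double-bonded ring carbon, with 5-methylthiophen-2-yl in place of 3,4-dimethoxyphenyl on a double-bonded chain carbon bound to a double-bonded ring carbon. The three measured steps all alter the group at this place, and none of them moved the number beyond the scatter. None of them, however, introduces a five-membered aromatic ring with 1 hetero atom, so the evidence is indirect. No shift beyond the scatter is therefore expected in this assay, and the expected change is a 1.1-fold lower number from compound 3 to compound 4 (0.03 log units; within the scatter). For compound 4 the estimated value is 160000 nM, with an expected range from 85000 nM to 290000 nM.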

Compound 4, half-maximal inhibitory concentration: 146000 nM
Estimate against measurement, compound 4: 1.1-fold (0.04 log units) above; measured number inside the range.
By their numbers in this assay, from the lowest: compounds 1, 4, 3 and 2 (each within the scatter of the next).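

In this assay the 5-methylthiophen-2-yl group, a five-membered aromatic ring with 1 hetero atom, differs in ring type from the three substituted phenyl groups seen before, yet every step to it stays within the scatter (a 1.2-fold lower number from compound 3 to compound 4 (0.07 log units; within the scatter)), (a 1.7-fold lower number from compound 2 to compound 4 (0.23 log units; within the scatter)) and (a 1.0-fold higher number from compound 1 to compound 4 (0.01 log units; within the scatter)). On a double-bonded chain carbon bound to a double-bonded ring carbon, these four compounds therefore tolerate a change of ring type, and also a drop from 10 heavy atoms in 3,4-dimethoxyphenyl to 6 in the entering group, without a shift beyond the scatter. Nothing available accounts for this lack of movement.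

The compounds shown leave open whether a carboxylic acid or an amine on the ring at this place, or a saturated alkyl chain in place of the ring, would move the number beyond the scatter. They also leave open whether changes elsewhere on the shared core would do so.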